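Solubility at the oxazolidinone side chain: compound 3

This account rests on a few compounds, and the source may have more. Where it says the series, first, only, none or still open, it means among the compounds named here.

Compound 1 `O=C1O[C@@H](CN2CCCCC2)CN1c1ccc(-n2cc(-c3ccccn3)cn2)c(F)c1` carries piperidin-1-yl on the side chain and gives 219000 nM in a physicochemical assay for solubility, read by HPLC, with a stated time of 24 h; a higher number here means a more soluble compound, a lower number a less soluble compound. Compound 2 `O=C(OC[C@H]1CN(c2ccc(-n3cc(-c4ccccn4)cn3)c(F)c2)C(=O)O1)c1ccccc1` carries benzoyloxy at the same place. In this assay compound 2 gives only a limit of the assay, <= 65400 nM. Within the data shown here, the one step measured so far, an at least 3.3-fold lower number from compound 1 to compound 2 (0.52 log units; beyond the scatter), is thus known only as a bound, set by the limit of <= 65400 nM in this assay, at which 1 of the 2 values shown sits. Compound 3 `O=C1O[C@@H](Cn2ccnn2)CN1c1ccc(-n2cc(-c3ccccn3)cn2)c(F)c1` differs from compound 2 by 1H-1,2,3-triazol-1-yl in place of benzoyloxy on a saturated chain carbon bound to a saturated ring carbon. Among the measured compounds shown here, no measured step exchanges benzoyloxy for a small aromatic heterocycle; the only step at hand, an at least 3.3-fold lower number from compound 1 to compound 2 (0.52 log units; beyond the scatter), shows the benzoyloxy compound at the limit while the piperidin-1-yl compound gives a number. An upward move in this assay is therefore expected for compound 3, about an at least 2.2-fold higher number from compound 2 to compound 3 (0.36 log units; beyond the scatter) against a limit. Compound 3 is estimated at 150000 nM in this assay, with a range of 40000 nM to 400000 nM.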

Compound 3, solubility: 247000 nM
Beside the measured number, compound 3's estimate is 1.6-fold (0.22 log units) below it; the measured number falls inside the stated range.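

Notes on the side chain: 1H-1,2,3-triazol-1-yl in place of benzoyloxy gives an at least 3.7-fold higher number from compound 2 to compound 3 (0.57 log units; beyond the scatter) in this assay, and this step is known only as a bound: the limit of <= 65400 nM in this assay, at which 1 of the 3 values shown sits.

Set against piperidin-1-yl at the same place, the triazole gives a 1.1-fold higher number from compound 1 to compound 3 (0.05 log units; within the scatter) in this assay and so leaves compound 1 and compound 3 level. A high number at this place is thus not tied to piperidin-1-yl; among the three compounds only compound 2, with benzoyloxy, stands apart.

On these data alone, how far compound 2 lies under its limit stays open, and with it the true size of both steps that involve it. Also open, as far as these compounds go, is whether a carboxylic acid, a morpholin-4-yl group or a 1H-1,2,3-triazol-1-yl on a longer chain would hold the number at this level.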